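This account rests on a few compounds, and the source may have more. Where it says the series, first, only, none or still open, it means among the compounds named here.

Measured so far:
Compound 1, `CCCC(Sc1nc(SC)c2cnn(-c3ccccc3)c2n1)C(N)=O`: in an assay for displacement of a labelled ligand from adenosine receptor A1 (Rattus norvegicus) (on this read-out higher numbers stand for weaker inhibition and lower numbers for stronger inhibition), compound 1 gives 7.55 nM.
Compound 2, `CCCCC(Sc1nc(S)c2cnn(-c3ccccc3)c2n1)C(N)=O`: in this assay compound 2 gives 37.2 nM.

Of these two numbers, compound 1 has the lowest, and so the stronger inhibition; compound 2 stands higher, a gap beyond the usual scatter. Compound 2 differs from compound 1 in more than one place, so the two values show only where each compound lands, not what any single change does.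

The next compound, compound 3, `CCC(Sc1nc(SC)c2cnn(-c3ccccc3)c2n1)C(N)=O`, has not yet been measured in this assay. Against compound 1 it differs in one place: hydrogen in place of methyl on a saturated chain carbon, three bonds along the chain from a carbonyl carbon and a sulfur. Put another way, the chain shrinks from propyl to ethyl. Among the compounds with values here, no step between measured compounds isolates this kind of change, so there is nothing to borrow a size from. Removing a single carbon from a chain usually moves this assay only a little, and if anything toward weaker inhibition. Compound 3 is therefore expected to come in near 11 nM, somewhere between 4 nM and 30 nM. The expected step of a 1.5-fold higher number from compound 1 to compound 3 (0.16 log units; within the scatter) is estimated to be small, at or just beyond the scatter.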

Compound 3, inhibition constant: 8.4 nM
Compound 3: middle estimate off by 1.3-fold (0.12 log units), on the high side; measured number inside the range.
By their numbers in this assay, from the lowest: compounds 1 and 3 (each within the scatter of the next); then compound 2.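

In this assay, the step from a propyl to an ethyl chain, with hydrogen in place of methyl on a saturated chain carbon, three bonds along the chain from a carbonyl carbon and a sulfur, gives a 1.1-fold higher number from compound 1 to compound 3 (0.05 log units; within the scatter). Within the data shown here, this is the first step that isolates a single change, and it shows that this assay cannot tell the two compounds apart: at this position, the end methyl of the propyl chain can go with no readable effect on inhibition. Nothing measured on these compounds says why this step is so small.

A single step cannot show how far this tolerance extends, so a still shorter methyl chain on the same core remains an open case, as do a chain ending in an amine and one ending in a carboxylic acid. A longer butyl chain is also unsettled, since compound 2 carries one but differs from compound 1 in more than one place and so cannot isolate the effect of chain length.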